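Working notes: plasma protein binding, compound 3 to compound 4

This account rests on a few compounds, and the source may have more. Where it says the series, first, only, none or still open, it means among the compounds named here.

Compound 3 `Cc1cc(Nc2ccc(S(F)(F)(F)(F)F)cc2)n2nc(C(C)(F)F)nc2n1` gives 97.4% in an ADME assay on a cell-free system (plasma, Homo sapiens) for protein binding, the largest unbound fraction of the three measured, although both gaps to it lie within the scatter. Compound 1 `Cc1cc(Nc2ccc(S(F)(F)(F)(F)F)cc2)n2nc(C3CC3)nc2n1` gives 97.7% and compound 2 `CSc1nc2nc(C)cc(Nc3ccc(S(F)(F)(F)(F)F)cc3)n2n1` gives 97.7%. The steps measured so far, no change at the digits printed from compound 1 to compound 2 (within the scatter), a 1.1-fold higher unbound fraction from compound 1 to compound 3 (0.05 log units; within the scatter) and a 1.1-fold higher unbound fraction from compound 2 to compound 3 (0.05 log units; within the scatter), each exchange the whole group on the aromatic carbon, and none moves the read-out beyond the scatter. Compound 4 `CCC(F)(F)c1nc2nc(C)cc(Nc3ccc(S(F)(F)(F)(F)F)cc3)n2n1` differs from compound 3 by methyl in place of hydrogen on a saturated chain carbon, two bonds along the chain from an aromatic carbon and two fluorine atoms. Within the data shown here, no measured step adds a methyl on a saturated chain carbon, so the expectation rests on the flat picture seen so far. Compound 4 is expected to give 97.8%, between 96.5% and 98.7%. The step a 1.2-fold lower unbound fraction from compound 3 to compound 4 (0.07 log units; within the scatter) is expected to stay within the scatter.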

Compound 4, plasma protein binding in the plasma assay: 97.7%
Estimate against measurement, compound 4: 1.0-fold (0.02 log units) (unbound fraction) below; measured number inside the range.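

In the plasma assay, the first methyl added on a saturated chain carbon, two bonds along the chain from an aromatic carbon and two fluorine atoms, taking compound 3 at 97.4% to compound 4 at 97.7% leaves the read-out within the scatter (a 1.1-fold lower unbound fraction from compound 3 to compound 4 (0.05 log units; within the scatter)), and 1,1-difluoropropyl matches both other groups on an aromatic carbon, with compound 2 at 97.7% and compound 1 at 97.7% (no change at the digits printed from compound 2 to compound 4 (within the scatter); no change at the digits printed from compound 1 to compound 4 (within the scatter)). In a physicochemical assay for solubility, at pH 6.5 (a lower number here means a less soluble compound, a higher number a more soluble compound), the same methyl also stays within the scatter, with compound 3 at 30000 nM and compound 4 at 15000 nM (a 2.0-fold lower number from compound 3 to compound 4 (0.30 log units; within the scatter)). No supporting data bear on the origin of these results. As far as these compounds go, whether a longer chain, an amine or a carboxylic acid at this chain position would move either read-out beyond the scatter remains open.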